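Replacing hydroxy with trifluoromethyl in compound 2

The compounds below may be only part of what the source reports. "The series", "measured", "known", "first", "only" and "open" are said of these compounds alone.

Measured in an in vitro ADME assay on microsomes (Rattus norvegicus) for metabolic stability; on this read-out lower numbers stand for a shorter-lived compound and higher numbers for a longer-lived compound:
- Compound 1 `CCc1nc(-c2ccc(OC)cc2OC(F)(F)F)c(CC)nc1NC(CC)CC`: 0.0683 h
- Compound 2 `CCc1nc(-c2ccc(OC)cc2O)c(CC)nc1NC(CC)CC`: 0.0983 h

Compound 2 stands within the scatter of compound 1, so these two values cannot be told apart. Compound 3 `CCc1nc(-c2ccc(OC)cc2C(F)(F)F)c(CC)nc1NC(CC)CC` has not yet been measured. It differs from compound 2 in one place: trifluoromethyl in place of hydroxy on an aromatic carbon, with trifluoromethyl in place of hydroxy on an aromatic carbon. Among the measured compounds shown here, no measured step makes this exact exchange. Going by the one step that bears on it, a 1.4-fold higher number from compound 1 to compound 2 (0.16 log units; within the scatter), with hydrogen in place of trifluoromethyl on an oxygen, no shift beyond the scatter is expected in this assay. The expected change is a 1.2-fold lower number from compound 2 to compound 3 (0.09 log units; within the scatter). For compound 3 the estimated value is 0.08 h, with an expected range from 0.045 h to 0.14 h.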

Compound 3, half-life: 0.0717 h
Estimate against measurement, compound 3: 1.1-fold (0.05 log units) above; the range from low to high includes it.
By their numbers in this assay, from the lowest: compounds 1, 3 and 2 (each within the scatter of the next).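

In this assay, trifluoromethyl in place of hydroxy on this aromatic carbon gives a 1.4-fold lower number from compound 2 to compound 3 (0.14 log units; within the scatter), and trifluoromethyl in place of trifluoromethoxy gives a 1.0-fold higher number from compound 1 to compound 3 (0.02 log units; within the scatter). Among the compounds shown here, the earlier pair compared only two groups attached through oxygen; this result adds a group attached directly through carbon, without the hydrogen-bond donor of hydroxy, and the half-life of all three compounds still cannot be told apart. Nothing available explains why these exchanges leave the read-out within the scatter.

The compounds shown leave open whether any group at this position would move the half-life beyond the scatter, for instance an amine, a carboxylic acid or a longer alkyl chain. They also leave open whether exchanges elsewhere on the shared core, such as at the methoxy group, would do so.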